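This account rests on a few compounds, and the source may have more. Where it says the series, first, only, none or still open, it means among the compounds named here.

In a functional assay on A549 cells (Homo sapiens) for antiproliferative activity, read by MTT assay (on this read-out higher numbers stand for weaker inhibition and lower numbers for stronger inhibition), the measured compounds stand as follows:
compound 1 `COc1ccc(NC(=O)Nc2cccc(CNc3ncnc4ccccc34)c2)cc1` gives 29300 nM;
compound 2 `COc1cc2ncnc(NCc3cccc(NC(=O)Nc4cccc(C)c4)c3)c2cc1OC` gives 27100 nM;
compound 3 `COc1cc2ncnc(NCc3cccc(NC(=O)Nc4ccccc4F)c3)c2cc1OC` gives 23800 nM.

Compound 3 carries the lowest of the three numbers, but its gaps to compound 2 and to compound 1 are both within the scatter, so no order among them can be claimed. Compound 4 `COc1cc2ncnc(NCc3cccc(NC(=O)Nc4ccc([N+](=O)[O-])cc4)c3)c2cc1OC` differs from compound 3 by 4-nitrophenyl in place of 2-fluorophenyl on an amide-type nitrogen. Going by the values given here, the only measured step at this place is a 1.1-fold lower number from compound 2 to compound 3 (0.06 log units; within the scatter), which exchanged one aryl group for another on the amide-type nitrogen without moving the number beyond the scatter. Among the compounds with values here, compound 1 and compound 2 differ in more than one place, so their values show only that both lie near compound 3. A step of about a 1.1-fold higher number from compound 3 to compound 4 (0.02 log units; within the scatter) is therefore expected, within the scatter. Compound 4 is estimated at 25000 nM, with a range from 10000 nM to 60000 nM.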

Compound 4, half-maximal inhibitory concentration: > 50000 nM
Compound 4 gave a limit, no number; the forecaster's own chance of this, stated with the estimate: 20%; middle value at least 2.0-fold (0.30 log units) away from the limit.
By their numbers in this assay, from the lowest: compounds 3, 2 and 1 (each within the scatter of the next). At a limit, above all of these: compound 4.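

In this assay, the aryl group on this amide-type nitrogen turns out to matter: 4-nitrophenyl in place of 2-fluorophenyl gives an at least 2.1-fold higher number from compound 3 to compound 4 (0.32 log units; beyond the scatter), the only step shown that lies beyond the scatter. Against 3-methylphenyl, the same group gives an at least 1.8-fold higher number from compound 2 to compound 4 (0.26 log units; that floor lies within the scatter), so that step alone shows no change. Compound 4 stands at a limit, not at a number: the limit of > 50000 nM in this assay, at which 1 of the 4 values shown sits.

Whether the change comes from the nitro group or from where the group sits stays open, since 4-fluorophenyl on this nitrogen is not among the compounds shown. From the compounds shown here alone, how 4-aminophenyl would read there also stays open.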